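A few compounds are considered here, and "the series" means these few. Any claim that something is new, unique, unknown or untested is made for them only; others in the source may bear on it.

The study brings together four compounds that share one core, two carrying a chloro group and two a methoxy group on the outer phenyl ring. Compound 1 `Clc1ccc(C2CC(c3ccccc3)=NN2c2ccc(-c3ccccc3)nn2)cc1` was tested in a functional assay on HepG2 cells (Homo sapiens) for antiproliferative activity, read by MTT assay, with a stated time of 24 h (a lower number here means a stronger inhibitor, a higher number a weaker inhibitor), where compound 1 gives 6310 nM. Compound 2 `COc1ccc(C2CC(c3ccccc3)=NN2c2ccc(-c3ccccc3)nn2)cc1` is related to compound 1 by methoxy in place of chloro on an aromatic carbon. In this assay compound 2 reaches only a limit of the assay, > 100000 nM. That change produced an at least 15-fold higher number from compound 1 to compound 2 (1.19 log units; beyond the scatter), a step whose size rests on (the limit of > 100000 nM in this assay, at which 1 of the 3 values shown sits).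

Compound 3 `Clc1ccc(C2=NN(c3ccc(-c4ccccc4)nn3)C(c3ccccc3)C2)cc1` holds the same atoms as compound 1, joined differently; the difference between the two cores is not broken down here. In this assay compound 3 gives 8750 nM, a value that lies within the usual scatter of what compound 1 gives.

Compound 4 `COc1ccc(C2=NN(c3ccc(-c4ccccc4)nn3)C(c3ccccc3)C2)cc1` stands to compound 3 as compound 2 stands to compound 1: it is related to compound 3 by methoxy in place of chloro on an aromatic carbon, the same change made on the other core. No measurement of compound 4 in this assay is yet in hand. The step from compound 3 to compound 4 is expected to be an 11-fold higher number from compound 3 to compound 4 (1.06 log units; beyond the scatter), because the same change gave an at least 15-fold higher number from compound 1 to compound 2 (1.19 log units; beyond the scatter). For compound 4 in this assay the estimate is 100000 nM, with a range from 30000 nM to 300000 nM, and it is quite possible that the assay will report only a limit for compound 4.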

Compound 4, half-maximal inhibitory concentration: > 100000 nM
Compound 4: no number, only a limit; the forecaster's own chance of this, stated with the estimate: 60%; the middle value lies on the limit itself.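

In this assay compound 4 gives only a limit of the assay, > 100000 nM, and not a number. The change from 4-chlorophenyl to 4-methoxyphenyl thus gives an at least 11-fold higher number from compound 3 to compound 4 (1.05 log units; beyond the scatter), so on both cores shown it goes the same way and lies beyond the scatter: the same change on two cores in this assay, an at least 15-fold higher number (1.19 log units; beyond the scatter) from compound 1 to compound 2 and an at least 11-fold higher number (1.05 log units; beyond the scatter) from compound 3 to compound 4; the limit leaves it open whether they differ. This does not show how large either step truly is, nor whether the two cores respond to the change equally, since both methoxy compounds rest on the same limit and not on numbers that could be set against each other: the limit of > 100000 nM in this assay, at which 2 of the 4 values shown sit.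

The compounds shown place only chloro and methoxy at this position, so they leave open how a fluoro group, a hydroxyl group or an amine would read there in this assay on either core. They also leave open whether a group such as a carboxylic acid or a longer chain like ethoxy would fall to the same limit, or would give measurable numbers that could show whether the two cores differ in their response to a change at this place.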